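The source may report more compounds than this note shows. Statements on the series, on what has been measured and on what is new or still open speak of the compounds shown alone.

Of the compounds shown here, three built around a shared core have been tested in a functional assay on the whole organism (blood, strain Wistar-Okamoto) with Rattus norvegicus as the target, with a stated time of 5 days; a lower number here means that less compound is needed, a higher number that more compound is needed for the effect. Compound 1 `CCCC/N=C(\NC#N)Nc1cccnc1` gives 20 mg/kg in this assay. Compound 2 `COc1ccc(N/C(=N/C(C)(C)C)NC#N)cn1` gives 15 mg/kg. Compound 3 `CC(C)CC(C)/N=C(\NC#N)Nc1ccncc1` gives 35 mg/kg, the highest of the three numbers: its gap to compound 1 lies within the scatter of this assay, so those two cannot be ordered, while its gap to compound 2 lies beyond the scatter, so compound 2 does need less compound than compound 3. Within the data shown here, no two of the measured compounds differ in a single place, so no direct step between them can be read off.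

Compound 4 `CC(C)(C)/N=C(\NC#N)Nc1ccncc1` differs from compound 3 in one place: tert-butyl in place of 1,3-dimethylbutyl on a double-bonded nitrogen. Compound 2 also carries a tert-butyl on a double-bonded nitrogen, and compound 2 gives 15 mg/kg, but its core is not the same, so that number is only a hint. A small move toward a lower number, possibly not beyond the scatter, is expected: a 1.8-fold lower number from compound 3 to compound 4 (0.24 log units; within the scatter). Compound 4 is therefore expected to give about 20 mg/kg, within a range from 8 mg/kg to 50 mg/kg.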

Compound 4, minimum effective dose: 2.5 mg/kg
Beside the measured number, compound 4's estimate is 8.0-fold (0.90 log units) above it; measured number below the stated range.
By their numbers in this assay, from the lowest: compound 4; then compounds 2, 1 and 3 (each within the scatter of the next, the first and the last beyond it).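

In this assay, putting tert-butyl in place of 1,3-dimethylbutyl on a double-bonded nitrogen gives a 14-fold lower number from compound 3 to compound 4 (1.15 log units; beyond the scatter). Among these compounds, this is the first direct reading of this position, and it shows that this one change alone can move the required dose by a large step, well beyond the scatter. The group that leaves has 6 heavy atoms and the one that enters has 4, both all carbon, but no measurement here explains the size of the step.

A single pair cannot separate the effect of chain size from that of branching. From the compounds shown here alone, it also remains open how other groups at this place, such as isopropyl or cyclopentyl, would compare with tert-butyl, and whether the same step would appear on another core.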